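This account rests on a few compounds, and the source may have more. Where it says the series, first, only, none or still open, it means among the compounds named here.

Measured in a physicochemical assay for lipophilicity, at pH 7.4; on this read-out lower numbers stand for lower lipophilicity and higher numbers for higher lipophilicity:
- Compound 1 `Cc1cc(C(=O)NN2CCCCC2)nn1Cc1cc(Cl)ccc1OCC(C)C`: 3.3
- Compound 2 `Cc1cc(NC(=O)C2CCCC2)nn1Cc1cc(Cl)ccc1OCC(C)C`: > 3.7

Within the data shown here, the entry for compound 2, > 3.7, is a limit of the assay and not a number. the limit of > 3.7 in this assay, at which 1 of the 2 values shown sits. The only measured step, a number at least 0.40 log units higher from compound 1 to compound 2 (beyond the scatter), has (cyclopentylcarbonyl)amino in place of (piperidin-1-yl)carbamoyl on an aromatic carbon.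

Compound 3 `Cc1cc(NC(=O)OC2CCOCC2)nn1Cc1cc(Cl)ccc1OCC(C)C` is not yet measured. It carries (oxan-4-yl)oxy in place of cyclopentyl on a carbonyl carbon. Cut one bond further out, the same difference reads cyclopentylcarbonyl to ((oxan-4-yl)oxy)carbonyl.

Among the measured compounds shown here, no measured step tests this exact swap, so the evidence is indirect. The entering group holds oxygen, whereas the leaving group holds only carbon. Going by the size of a number at least 0.40 log units higher from compound 1 to compound 2 (beyond the scatter), a move downward of a similar scale is expected in this assay, although the starting point has no exact number. The expected change is a number at least 0.10 log units lower from compound 2 to compound 3 (that floor lies within the scatter). For compound 3 the estimated value is 3.6, with an expected range of 3.1 to 4.1.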

Compound 3, distribution coefficient: 3.4
Compound 3: middle estimate off by 0.20 log units, on the high side, within the range that was stated.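

The earlier pair changed the whole link to the shared core, whereas this result isolates the group on a carbonyl carbon whose other neighbour is amide-type nitrogen. In this assay, (oxan-4-yl)oxy in place of cyclopentyl gives a number at least 0.30 log units lower from compound 2 to compound 3 (that floor lies within the scatter). For compound 2 the entry is a limit of the assay and not a number, so the step has only a floor and its true size cannot be read: the limit of > 3.7 in this assay, at which 1 of the 3 values shown sits. The swap also changes several features at once: the entering group has a six-membered ring with 1 hetero atom, 2 oxygen atoms and 2 hydrogen-bond acceptors, while the leaving group has a five-membered ring of carbon only and 0 hydrogen-bond acceptors.

The compounds shown leave open how much of the step goes with the ring oxygen and how much with the oxygen that joins the ring to the carbonyl carbon. Cyclopentyloxy or oxan-4-yl on the same carbonyl carbon would each differ from compound 3 in one place and could separate those two contributions.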